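The source may report more compounds than this note shows. Statements on the series, on what has been measured and on what is new or still open speak of the compounds shown alone.

Measured so far in a functional assay on BGC-823 cells (Homo sapiens) for antiproliferative activity, read by MTT assay, tested at 5 uM; on this read-out higher numbers stand for a stronger effect at the one concentration tested and lower numbers for a weaker effect:

- compound 1 `COc1ccc(/C=N/NC(=O)c2cc(OC)c(OC)c(OC)c2)c(OC)c1` gives 3.6%
- compound 2 `COc1cc(C2=NN(C(C)=O)C(c3cc(Cl)cc(Cl)c3)O2)cc(OC)c1OC` gives 6.6%
- compound 3 `COc1cc(C(=O)N/N=C/c2ccccc2C(F)(F)F)cc(OC)c1OC` gives 35.6%

Compound 2 stands second highest of these three numbers. Its nearest neighbour is compound 1, whose value 3.6% lies within the usual scatter of this read-out, so no order between compound 1 and compound 2 can be claimed. Its furthest neighbour is compound 3, whose value 35.6% lies beyond the scatter; only compound 3 rises clearly above the other two at the single concentration tested.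

The next compound, compound 4 `COc1cc(C2=NN(C(C)=O)C(c3ccc(Cl)c(Cl)c3)O2)cc(OC)c1OC`, has not been measured in this assay. It differs from compound 2 in one place: 3,4-dichlorophenyl in place of 3,5-dichlorophenyl on a saturated ring carbon. The two compounds share the same atoms, joined differently; nothing else changes.

Among the measured compounds shown here, no pair of measured compounds differs in one place, so no step is available to calibrate how much such a change moves the read-out. With compound 2 low and compound 1 low as well, the expectation for compound 4 is a step of no more than the scatter in either direction, that is none beyond the scatter. Compound 4 is therefore expected to give about 8%, within the range 0% to 25%. The corresponding expected step is a number 1.4 percentage points higher from compound 2 to compound 4 (within the scatter).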

Compound 4, a percentage reported as inhibition, at one concentration (the size of the read-out at that concentration, not a potency): 3.1%
For compound 4 the middle estimate is 4.9 percentage points above the measured one; the measured number falls inside the stated range.
By their numbers in this assay, from the lowest: compounds 4, 1 and 2 (each within the scatter of the next); then compound 3.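

In this assay, among the compounds shown here, 3,4-dichlorophenyl in place of 3,5-dichlorophenyl on the saturated ring carbon gives a number 3.5 percentage points lower from compound 2 to compound 4 (within the scatter), which is the first one-place step available. This exchange keeps the same atoms and the same counts of the group, and here the two chlorine patterns cannot be told apart at the single concentration tested. For the compounds shown here, since both compounds lie low on this read-out, the step shows only that this one exchange does not raise the effect beyond the scatter, and no measured property is available to account for the outcome.

The compounds shown leave open whether this ring carbon tolerates anything other than a dichlorophenyl group, for example a phenyl ring carrying a dimethylamino group or a carboxylic acid, or a plain unsubstituted phenyl, and whether any such group would lift the read-out clear of the scatter. Also open, going by these compounds, is whether the acetyl group on the neighbouring ring atom matters, which a longer chain such as butanoyl in its place would test.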